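The source may hold more compounds than are shown below. What is called first, only, known or untested is meant among the compounds shown, and "the series" means these compounds.

Measured so far in an ADME assay on Huh-7 cells (Homo sapiens) for cytotoxicity, read by MTT assay, with a stated time of 3 days; a higher number here means that more compound is tolerated, a lower number that less compound is tolerated:
Compound 1 `CCCNNC(=O)c1ccc(-c2ccccc2)cc1` gives 5900 nM.
Compound 2 `Cc1nc2ccccc2n1Cc1ccc(C(=O)NO)cc1` gives 7900 nM.
Compound 3 `O=C(NO)c1ccc(-c2ccccc2)cc1` gives 30000 nM.

Compound 4 `CCCNNC(=O)c1ccc(Cn2c(C)nc3ccccc32)cc1` is not yet measured. It differs from compound 2 by propylamino in place of hydroxy on an amide-type nitrogen. The same change is seen once before, from compound 3 to compound 1, as propylamino in place of hydroxy on an amide-type nitrogen, and there it made a 5.1-fold lower number from compound 3 to compound 1 (0.71 log units; beyond the scatter). The difference between the cores of compound 2 and compound 3 is not broken down here; the numbers for compound 2 and compound 1 lie within the scatter of each other, while compound 2 and compound 3 lie beyond it. Within the data shown here, with only that single precedent and a different core, the expectation for compound 4 is a step of a 4.0-fold lower number from compound 2 to compound 4 (0.60 log units; beyond the scatter), resting on the size of a 5.1-fold lower number from compound 3 to compound 1 (0.71 log units; beyond the scatter). Compound 4 is therefore estimated at 2000 nM, between 800 nM and 6000 nM.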

Compound 4, half-maximal cytotoxic concentration: 9900 nM
Beside the measured number, compound 4's estimate is 5.0-fold (0.69 log units) below it, outside the stated range (above it).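

In this assay, propylamino in place of hydroxy on the amide-type nitrogen does not carry over from one core to the other at a fixed size: the same change on two cores in this assay, a 5.1-fold lower number (0.71 log units; beyond the scatter) from compound 3 to compound 1 and a 1.3-fold higher number (0.10 log units; within the scatter) from compound 2 to compound 4, 6.4-fold (0.80 log units) apart, beyond the scatter of two such steps. On the core of compound 2 the step is a 1.3-fold higher number from compound 2 to compound 4 (0.10 log units; within the scatter), so the drop seen on the other core does not appear here. With one pair per core, neither step can be called typical, and the numbers show no reason for the gap.

The compounds shown leave open how a shorter chain such as ethylamino or a longer chain such as butylamino would behave on the same nitrogen on either core. They also leave open which of the two steps a third core would follow.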